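Chlorine shift on the benzyl group of compound 3

The compounds below may be only part of what the source reports. "The series", "measured", "known", "first", "only" and "open" are said of these compounds alone.

In a physicochemical assay, read by spectrophotometry, with a stated time of 30 min (a lower number here means a stronger inhibitor, a higher number a weaker inhibitor), compound 1 (`Clc1cccc(Cn2cc(COc3ccccc3)nn2)c1`) gives 27.3 ug/mL and compound 2 (`O=[N+]([O-])c1cccc(Cn2cc(COc3cccc([N+](=O)[O-])c3)nn2)c1`) gives 19.1 ug/mL as the two reference points for the series. Compound 3 (`O=[N+]([O-])c1cccc(OCc2cn(Cc3ccc(Cl)cc3)nn2)c1`) gives 37.3 ug/mL in the same assay. That value lies within the scatter of both others, so the three compounds do not separate on these numbers.

Compound 4 (`O=[N+]([O-])c1cccc(OCc2cn(Cc3cccc(Cl)c3)nn2)c1`) has the same atoms as compound 3, joined differently: 3-chlorophenyl in place of 4-chlorophenyl on a saturated chain carbon bound to an aromatic nitrogen with 3-chlorophenyl in place of 4-chlorophenyl on a saturated chain carbon bound to an aromatic nitrogen. Cut one bond further out, this reads 4-chlorobenzyl to 3-chlorobenzyl.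

For the measured compounds named here, no measured pair isolates this change, so its size in this assay has no direct support. Compound 1 also carries a 3-chlorobenzyl group and gives 27.3 ug/mL but differs from compound 4 elsewhere in its structure. The expectation is therefore no step beyond the scatter, with at most a slight lean towards a lower number. The expected change is a 1.2-fold lower number from compound 3 to compound 4 (0.09 log units; within the scatter) and is not expected to be separable from repeat variation. For compound 4 the estimated value is 30 ug/mL with an expected range of 16 ug/mL to 52 ug/mL for the measurement.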

Compound 4, half-maximal inhibitory concentration: 31.2 ug/mL
Beside the measured number, compound 4's estimate is 1.0-fold (0.02 log units) below it; the measured number falls inside the stated range.
By their numbers in this assay, from the lowest: compounds 2, 1, 4 and 3 (each within the scatter of the next).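

In this assay the chlorine shift gives a 1.2-fold lower number from compound 3 to compound 4 (0.08 log units; within the scatter) and is now a direct read: 3-chlorophenyl in place of 4-chlorophenyl on a saturated chain carbon bound to an aromatic nitrogen does not separate from repeat variation. For the compounds shown here, compound 4 also connects the earlier compounds through single changes, which they did not offer among themselves: chloro in place of nitro on an aromatic carbon gives a 1.6-fold higher number from compound 2 to compound 4 (0.21 log units; within the scatter) and nitro in place of hydrogen on an aromatic carbon gives a 1.1-fold higher number from compound 1 to compound 4 (0.06 log units; within the scatter) with both steps likewise within the scatter, so none of the three changes shifts the number measurably in this small set. No supporting measurement is available to explain these results.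

Going by these compounds, only chloro, nitro and hydrogen appear as substituents on the aromatic rings here, so the effect of an amine or a carboxylic acid in those places remains open. On these data alone, the group on the aromatic nitrogen appears only as a substituted benzyl, and a longer chain ending in the same chlorophenyl is an equally open question.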